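Cyclic sulfonamide to methylsulfonyl on a shared core

The compounds below may be only part of what the source reports. "The series", "measured", "known", "first", "only" and "open" are said of these compounds alone.

Compound 1, `CC(C)c1noc(N2CCC(Oc3cc(N4CCc5cc(C6CCCCC6=O)ccc54)ncn3)CC2)n1`: 78 mL.min-1.g-1
Compound 2, `CCc1cnc(N2CCC(C(C)COC(=O)N3CCc4cc(S(C)(=O)=O)cc(F)c43)CC2)nc1`: 329 mL.min-1.g-1
Compound 3, `CC(C)c1noc(N2CCC(Oc3cc(N4CCc5cc(N6CCCS6(=O)=O)ccc54)ncn3)CC2)n1`: 18 mL.min-1.g-1

Three compounds have been run through an ADME assay on microsomes from liver (Homo sapiens) for metabolic stability, read by LC-MS, using NADPH, with a stated time of 30 min, tested at 1 uM; on this read-out lower numbers stand for slow clearance and higher numbers for fast clearance. Compound 3 stands lowest of the three, with compound 1 nearest and compound 2 furthest away; both gaps lie beyond the scatter. For the measured compounds named here, the only one-place step among them is a 4.3-fold lower number from compound 1 to compound 3 (0.64 log units; beyond the scatter), a modest change that comes with the cyclic sulfonamide replacing the cyclohexanone on the shared core.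

Compound 4, `CC(C)c1noc(N2CCC(Oc3cc(N4CCc5cc(S(C)(=O)=O)ccc54)ncn3)CC2)n1`, keeps the core of compound 3 and changes one group: a group of 4 heavy atoms (1 carbon, 2 oxygen, 1 sulfur; no ring) in place of a group of 7 heavy atoms (3 carbon, 1 nitrogen, 2 oxygen, 1 sulfur; one five-membered non-aromatic ring with 2 hetero atoms), on an aromatic carbon. Going by the values given here, compound 2 also carries a methylsulfonyl, but on a different core, and so its number in this assay, 329 mL.min-1.g-1, says only where that compound lands and carries no one-place step to compound 3 or compound 4. Among the compounds with values here, the single measured step bears on the present change only indirectly, since it swaps the cyclic sulfonamide in rather than out; no step shows what happens when a methylsulfonyl takes its place. The step from compound 3 to compound 4 is therefore expected to be small, at most a little upward, as a 1.6-fold higher number from compound 3 to compound 4 (0.19 log units; within the scatter). Compound 4 is estimated at 28 mL.min-1.g-1 in this assay, within 10 mL.min-1.g-1 to 80 mL.min-1.g-1.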

Compound 4, intrinsic clearance in microsomes: 69 mL.min-1.g-1
For compound 4 the middle estimate is 2.5-fold (0.39 log units) below the measured one; low and high end bracket the measured number.
By their numbers in this assay, from the lowest: compound 3; then compounds 4 and 1 (each within the scatter of the next); then compound 2.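

In this assay, this place on the aromatic carbon now has a direct reading for methylsulfonyl against the five-membered cyclic sulfonamide: the step (a 3.8-fold higher number from compound 3 to compound 4 (0.58 log units; beyond the scatter)) shows that the two groups are not interchangeable here, although they have the same counts of double bonds outside aromatic rings, hydrogen-bond donors and hydrogen-bond acceptors. Methylsulfonyl and 2-oxocyclohexyl cannot be told apart at this place (a 1.1-fold lower number from compound 1 to compound 4 (0.05 log units; within the scatter)), so of the three groups seen here only the cyclic sulfonamide stands apart, with its step from the cyclohexanone compound (a 4.3-fold lower number from compound 1 to compound 3 (0.64 log units; beyond the scatter)) and its step to the methylsulfonyl compound both beyond the scatter. Nothing at hand explains why the cyclic sulfonamide gives the lowest number of the three.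

The compounds shown leave open whether that lower number needs the ring itself or only a sulfonyl group joined through nitrogen, which an open-chain methanesulfonamide or a six-membered cyclic sulfonamide at the same place could separate. They also leave open whether the step from the cyclic sulfonamide to methylsulfonyl would be of similar size on a different core, such as that of compound 2.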